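The compounds below may be only part of what the source reports. "The series", "measured", "known", "first", "only" and "open" are said of these compounds alone.

Three compounds have been measured in a functional assay on HepG2 cells (Homo sapiens) for cytotoxicity, read by MTT assay, with a stated time of 48 h; on this read-out higher numbers stand for weaker inhibition and lower numbers for stronger inhibition:

compound 1, `CCCCCCCCCCCCCCNC(=O)[C@@H](NC(=O)c1cccs1)[C@@H](C)O`, giving 88400 nM;
compound 2, `CCCCCCCCCCCCCCNC(=O)[C@@H](NC(=O)c1cc2ccccc2[nH]1)[C@@H](C)O`, giving 10500 nM;
compound 3, `CCCCCCCCCCCCCCNC(=O)[C@@H](NC(=O)c1cc2ccccc2n1C)[C@@H](C)O`, giving 34500 nM.

Compound 3 stands second highest of the three numbers. It sits below compound 1, the step being a 2.6-fold lower number from compound 1 to compound 3 (0.41 log units; beyond the scatter), and above compound 2, as shown by a 3.3-fold higher number from compound 2 to compound 3 (0.52 log units; beyond the scatter); both steps lie beyond the scatter.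

Compound 4, `C/C=C/C=C/C(=O)N[C@H](C(=O)NCCCCCCCCCCCCCC)[C@@H](C)O`, has not yet been measured. It differs from compound 3 in one place: penta-1,3-dien-1-yl in place of 1-methyl-1H-indol-2-yl on a carbonyl carbon.

For the measured compounds named here, two measured steps bear on this exchange, since each swaps the group on that same carbonyl carbon: an 8.4-fold lower number from compound 1 to compound 2 (0.93 log units; beyond the scatter) and a 2.6-fold lower number from compound 1 to compound 3 (0.41 log units; beyond the scatter). Both moved the number beyond the scatter, and thiophen-2-yl in compound 1 gave the highest number of the three. Penta-1,3-dien-1-yl brings no ring at all, so a rise in this assay is expected, beyond the scatter. Compound 4 is therefore expected to give 70000 nM. For compound 4 the estimated range runs from 25000 nM to 200000 nM. The expected step is a 2.0-fold higher number from compound 3 to compound 4 (0.31 log units; beyond the scatter).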

Compound 4, half-maximal inhibitory concentration: > 400000 nM
Compound 4 was reported as a limit; the forecaster's own chance of this, stated with the estimate: 25%; at least 5.7-fold (0.75 log units) between middle value and limit.
By their numbers in this assay, from the lowest: compound 2; then compound 3; then compound 1. At a limit, above all of these: compound 4.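

In this assay, compound 4 is recorded only as a limit, not as a number: the limit of > 400000 nM in this assay, at which 1 of the 4 values shown sits.

This shows that the group on this carbonyl carbon can do more than move the number among aromatic rings, since exchanging each ring group for the open penta-1,3-dien-1-yl gives an at least 11-fold higher number from compound 3 to compound 4 (1.06 log units; beyond the scatter), an at least 38-fold higher number from compound 2 to compound 4 (1.58 log units; beyond the scatter) and an at least 4.5-fold higher number from compound 1 to compound 4 (0.65 log units; beyond the scatter). The three compounds with an aromatic ring at this place all give a number, whereas compound 4, with no ring, gives only a limit, though a single compound cannot show that the ring alone decides this.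

The compounds shown leave open what a saturated pentyl chain or a plain phenyl ring would give at this place in this assay. They also cannot separate the loss of the ring from the arrival of the two double bonds.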